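The compounds below may be only part of what the source reports. "The series", "measured", "known", "first", "only" and "open" are said of these compounds alone.

Measured so far in a functional assay on HeLa cells (Homo sapiens) for cytotoxicity, read by sulforhodamine B assay, with a stated time of 48 h; on this read-out lower numbers stand for stronger inhibition and higher numbers for weaker inhibition:
- compound 1 `COc1ccc(/C=C/C(=O)/C=C/C2=C(C)CCCC2(C)C)cc1` gives 15700 nM
- compound 2 `CC1=C(/C=C/C(=O)/C=C/c2ccc([N+](=O)[O-])cc2)C(C)(C)CCC1` gives 28700 nM
- compound 3 `COc1ccccc1/C=C/C(=O)/C=C/C1=C(C)CCCC1(C)C` gives 88200 nM

Compound 2 differs from compound 1 by nitro in place of methoxy on an aromatic carbon, a step of a 1.8-fold higher number from compound 1 to compound 2 (0.26 log units; within the scatter). Compound 3 has the highest number of the three; how its core differs from that of compound 1 is not broken down here.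

Compound 4 `CC1=C(/C=C/C(=O)/C=C/c2ccccc2[N+](=O)[O-])C(C)(C)CCC1` is not yet measured. It differs from compound 3 by nitro in place of methoxy on an aromatic carbon. This is the same kind of change as from compound 1 to compound 2, but the place is not the same: there the nitro sits para to a large group, here ortho to a large group.

Among the measured compounds shown here, the expectation for compound 4 in this assay rests on the one earlier step, because a 1.8-fold higher number from compound 1 to compound 2 (0.26 log units; within the scatter) was within the scatter; a step of about a 1.5-fold higher number from compound 3 to compound 4 (0.17 log units; within the scatter) from compound 3 is expected. Compound 4 is thus estimated at 130000 nM, with a likely range from 60000 nM to 300000 nM.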

Compound 4, half-maximal inhibitory concentration: 36100 nM
For compound 4 the middle estimate is 3.6-fold (0.56 log units) above the measured one, outside the stated range (below it).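

Nitro in place of methoxy gives a 2.4-fold lower number from compound 3 to compound 4 (0.39 log units; beyond the scatter) in this assay. Set beside the earlier step, the same change does not carry over from one core to the other as a fixed step: the same change on two cores in this assay, a 1.8-fold higher number (0.26 log units; within the scatter) from compound 1 to compound 2 and a 2.4-fold lower number (0.39 log units; beyond the scatter) from compound 3 to compound 4, 4.5-fold (0.65 log units) apart, beyond the scatter of two such steps Two steps show only that the outcome of this change depends on the core it is made on; they do not show what sets the difference, since the nitro in compound 4 is ortho to a large group and in compound 2 it is placed otherwise.

Open, from the compounds shown here alone, is how other groups on the aromatic ring, such as an amine or a carboxylic acid, would behave on these two cores. Also open, going by these compounds, is whether any further core would follow compound 2 or compound 4.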